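Hydrazone series on the shared core: halogen versus dimethylamino aryl

The source may report more compounds than this note shows. Statements on the series, on what has been measured and on what is new or still open speak of the compounds shown alone.

Measured so far:
compound 1 `Clc1ccccc1/C=N/Nc1nc2ccccc2nc1Cc1ccccc1`: 87000 nM
compound 2 `CN(C)c1ccc(/C=N/Nc2nc3ccccc3nc2Cc2ccccc2)cc1`: 880000 nM

In an assay on isolated protein for inhibition of Amine oxidase [flavin-containing] B (Homo sapiens), read by spectrophotometry (on this read-out lower numbers stand for stronger inhibition and higher numbers for weaker inhibition), compound 2 gives the highest of the two numbers; compound 1 sits at a 10-fold higher number from compound 1 to compound 2 (1.00 log units; beyond the scatter) from it. Compound 3 `Brc1cccc(/C=N/Nc2nc3ccccc3nc2Cc2ccccc2)c1` differs from compound 2 by 3-bromophenyl in place of 4-(dimethylamino)phenyl on a carbon with a double bond to nitrogen. Within the data shown here, the only step that bears on this is the one from compound 1 to compound 2, which moved the number upward; going from a dimethylamino aryl to a halogenated aryl reverses that kind of change, so a downward step is expected, somewhat short of a full return. Compound 3 is estimated at 150000 nM (range 40000 nM to 600000 nM), an expected step of a 5.9-fold lower number from compound 2 to compound 3 (0.77 log units; beyond the scatter).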

Compound 3, half-maximal inhibitory concentration: 48000 nM
Compound 3: the middle estimate sits 3.1-fold (0.49 log units) above what was measured, within the range that was stated.
By their numbers in this assay, from the lowest: compounds 3 and 1 (each within the scatter of the next); then compound 2.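

In this assay, 3-bromophenyl in place of 4-(dimethylamino)phenyl gives an 18-fold lower number from compound 2 to compound 3 (1.26 log units; beyond the scatter), so a second halogenated aryl also stands clear of the dimethylamino aryl at this carbon with a double bond to nitrogen. Between the two halogenated aryls there is only a 1.8-fold lower number from compound 1 to compound 3 (0.26 log units; within the scatter), which gives them no order. Nothing available accounts for either step.

Halogen identity and ring placement change together between the two halogenated aryls, so their separate contributions remain open. Also open, from the compounds shown here alone, is where an unsubstituted phenyl or a methoxyphenyl would fall.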